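A bromo for methyl swap at the assay limit

The compounds below may be only part of what the source reports. "The series", "measured", "known", "first", "only" and "open" are said of these compounds alone.

Both values below, from an ADME assay on HeLa cells (Homo sapiens) for cytotoxicity, read by resazurin assay, with a stated time of 2 days (on this read-out higher numbers stand for weaker inhibition and lower numbers for stronger inhibition), are limits.
Compound 1 `Cn1c([N+](=O)[O-])cnc1/C=C/c1ccccc1` gives > 100000 nM as a limit
Compound 2 `Cc1ccc(/C=C/c2ncc([N+](=O)[O-])n2C)cc1` gives > 100000 nM as a limit

Compound 2 has > 100000 nM as a limit and no number. The move to compound 3 `Cn1c([N+](=O)[O-])cnc1/C=C/c1ccc(Br)cc1` is bromo in place of methyl on an aromatic carbon and puts bromo in place of methyl on an aromatic carbon. Among the compounds with values here, the only measured step that bears on it is a step that the two limits leave unreadable from compound 1 to compound 2 and it gives no size. Within the data shown here, with the limit of > 100000 nM in this assay, at which 2 of the 2 values shown sit, as the only guide, no step beyond the scatter is expected in this assay in either direction. The expected change is a number no higher from compound 2 to compound 3 (the limit leaves the size open) and no more. Compound 3 is estimated at 100000 nM with an expected range from 50000 nM to 200000 nM.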

Compound 3, half-maximal inhibitory concentration: 72400 nM
Compound 3: middle estimate off by 1.4-fold (0.14 log units), on the high side; measured number inside the range.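

In this assay compound 3, with bromo on the six-membered aromatic ring, is the only compound shown that gives a number, 72400 nM, rather than a limit. Bromo in place of methyl gives an at least 1.3-fold lower number from compound 2 to compound 3 (0.14 log units; that floor lies within the scatter), and bromo in place of hydrogen gives an at least 1.3-fold lower number from compound 1 to compound 3 (0.14 log units; that floor lies within the scatter). Each is only a floor, and the true size of neither step is known: the limit of > 100000 nM in this assay, at which 2 of the 3 values shown sit.

The step between compound 1 and compound 2 cannot be read. On these data alone, how a chloro, an amine or a carboxylic acid at this position would read in this assay remains open.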